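The source may report more compounds than this note shows. Statements on the series, on what has been measured and on what is new or still open speak of the compounds shown alone.

Compound 1 `Cn1nnnc1SCC(=O)N/N=C/c1ccccc1F` and compound 2 `Cn1nnnc1SCC(=O)N/N=C/c1cccc(F)c1` share one core and carry the same fluorine on the terminal ring, placed differently. In an ADME assay on NIH3T3 cells (Mus musculus) for cytotoxicity, read by XTT assay, with a stated time of 24 h (a higher number here means a weaker inhibitor, a lower number a stronger inhibitor), compound 1 gives 2000000 nM, and compound 2 gives 6320000 nM. Compound 2 thus stands at the higher of the two numbers, and its gap to compound 1 lies beyond the usual scatter of repeated measurements of this kind. The next compound, compound 3 `Cn1nnnc1SCC(=O)N/N=C/c1cccc(O)c1`, has not yet been run in this assay. It differs from compound 2 in one place: hydroxy in place of fluoro on an aromatic carbon. Within the data shown here, no measured pair shows what this exchange does, so any expectation can rest only on the two numbers at hand and on the modest size of the change. For compound 3 the expected step is a 1.4-fold lower number from compound 2 to compound 3 (0.15 log units; within the scatter), a small movement to a lower number that need not reach beyond the scatter. In this assay compound 3 is therefore expected to give 4500000 nM, with a range from 1500000 nM to 14000000 nM.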

Compound 3, half-maximal inhibitory concentration: 3160000 nM
Estimate against measurement, compound 3: 1.4-fold (0.15 log units) above; the range from low to high includes it.
By their numbers in this assay, from the lowest: compounds 1, 3 and 2 (each within the scatter of the next, the first and the last beyond it).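

Where the earlier compounds showed only what moving fluoro around the terminal ring does, compound 3 gives the first reading of a different group at this place, on an aromatic carbon of the ring, meta to a large group: in this assay the exchange of fluoro for hydroxy is a 2.0-fold lower number from compound 2 to compound 3 (0.30 log units; within the scatter) and so cannot be told from repeat measurement. The exchange adds a hydrogen-bond donor and a hydrogen-bond acceptor to a spot where fluoro counts neither, yet with this single pair, the numbers of compound 2 and compound 3 stay within the scatter of each other, so at this position in this assay the two groups are not separated. Nothing at hand offers an explanation for this reading, and it remains an observation on one pair.

The compounds shown leave open whether an amine, a methoxy group or a carboxylic acid on the same carbon would carry the number beyond the scatter. They also leave open whether hydroxy would read the same on the carbon that holds fluoro in compound 1, whose number stands apart from that of compound 2.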